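The source may hold more compounds than are shown below. What is called first, only, known or untested is meant among the compounds shown, and "the series" means these compounds.

Compound 1, `Cc1nc(C)n2c(S)nncc12`: in a functional assay for inhibition, with Homo sapiens as the target (on this read-out lower numbers stand for stronger inhibition and higher numbers for weaker inhibition), compound 1 gives > 48000 nM, which is a limit of the assay.
Compound 2, `CCCc1nc(C)c2c(CC)nnc(S)n12`: in this assay compound 2 gives > 48000 nM, again a limit of the assay.
Compound 3, `CCCc1nc(C)c2cnnc(NCCN(C)C)n12`: in this assay compound 3 gives > 48000 nM, once more a limit of the assay.

Compound 3 therefore holds no distinct place among the numbers shown: its result is only a limit, and the two other results are limits as well, so that every value sits at the limit of > 48000 nM in this assay, at which 3 of the 3 values shown sit. Among the compounds with values here, no two measured compounds differ in a single place, so no measured step can be given a size or a direction here.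

The unmeasured compound 4, `CCCc1nc(C)c2cnnc(S)n12`, differs from compound 3 by sulfanyl in place of (2-(dimethylamino)ethyl)amino on an aromatic carbon. Compound 1 and compound 2 likewise carry a sulfanyl group on their cores, and each of them returned only a limit. In this assay the expected step is a step that the limit leaves unreadable from compound 3 to compound 4, that is, none beyond the usual scatter. For compound 4 the estimate in this assay is 60000 nM, with a range from 30000 nM to 150000 nM, and the assay is expected most likely to report only a limit once more.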

Compound 4, half-maximal inhibitory concentration: 10000 nM
Estimate against measurement, compound 4: 6.0-fold (0.78 log units) above; measured number outside the range, below it.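

Within the data shown here, at the aromatic carbon between two ring nitrogen atoms, sulfanyl in place of (2-(dimethylamino)ethyl)amino gives an at least 4.8-fold lower number from compound 3 to compound 4 (0.68 log units; beyond the scatter) in this assay, the first sign that a change at this position can register in the assay. Sulfanyl alone is not enough, as compound 1 and compound 2 also carry it: hydrogen in place of ethyl on an aromatic carbon gives an at least 4.8-fold lower number from compound 2 to compound 4 (0.68 log units; beyond the scatter), and ethyl in place of hydrogen on a saturated chain carbon bound to an aromatic carbon gives an at least 4.8-fold lower number from compound 1 to compound 4 (0.68 log units; beyond the scatter). Each of these three steps has only a lower bound on its size, and compound 4 is the only compound with a number that is not a limit: the limit of > 48000 nM in this assay, at which 3 of the 4 values shown sit.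

The compounds shown leave open how a hydroxyl, a methylthio group or a shorter amine on this carbon would read, so the step cannot be assigned to the sulfur atom itself or to the loss of the chain. They also leave open how a longer chain would read at the place where compound 1 and compound 4 differ, and how large any of the three steps really is.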